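This account rests on a few compounds, and the source may have more. Where it says the series, first, only, none or still open, it means among the compounds named here.

Compound 1, whose structure is `O=C(CSc1nnc(-c2ccncc2)s1)Nc1ccc(Cl)cc1`, was tested in an ADME assay on HepG2 cells (Homo sapiens) for cytotoxicity, with a stated time of 3 days; a higher number here means that more compound is tolerated, a lower number that less compound is tolerated. In this assay compound 1 reached only the limit of the measurement, giving > 50000 nM, so no exact number is known for it. Two related compounds were examined alongside it. Compound 2, with the structure `CC(CSc1nnc(-c2ccncc2)s1)C(=O)Nc1c(Cl)cccc1Cl`, likewise reached only a limit in this assay, at > 50000 nM. Compound 3, with the structure `O=C(CCSc1nnc(-c2ccncc2)s1)Nc1ccccc1Cl`, also gave no more than a limit in this assay, at > 50000 nM. What all three share is the limit of > 50000 nM in this assay, at which 3 of the 3 values shown sit, so none of them shows measurable cytotoxicity within the range covered.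

Compound 4, whose structure is `O=C(CSc1nnc(-c2ccncc2)s1)Nc1ccccc1Cl`, differs from compound 1 in one place: 2-chlorophenyl in place of 4-chlorophenyl on an amide-type nitrogen. Going by the values given here, since the change moves the same chlorine around the same aromatic ring and no measured compound has left the limit, the step that the limit leaves unreadable from compound 1 to compound 4 is expected to be none beyond the scatter, and compound 4 is expected to give about 60000 nM in this assay, most likely between 20000 nM and 200000 nM, again probably as a limit rather than a number.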

Compound 4, half-maximal cytotoxic concentration: > 50000 nM
Compound 4 ended at the assay's limit; the forecaster's own chance of this, stated with the estimate: 85%; the middle value does not contradict the limit.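

Compound 1 and compound 4 both end at a limit in this assay, so no size can be read for the change from 4-chlorophenyl to 2-chlorophenyl: the limit of > 50000 nM in this assay, at which 4 of the 4 values shown sit.

The compounds shown leave open at what concentration, if any, each one would harm these cells, and whether moving the chlorine changes that.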